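Replacing the trimethylphenyl group of compound 3

The compounds below may be only part of what the source reports. "The series", "measured", "known", "first", "only" and "open" are said of these compounds alone.

In a functional assay on KB cells (Homo sapiens) for antiproliferative activity, read by sulforhodamine B assay, with a stated time of 3 days (on this read-out higher numbers stand for an effect only at larger amounts of compound and lower numbers for an effect already at smaller amounts), compound 1 `CCC1=C(O)c2c(oc(-c3ccc(F)cc3)cc2=O)C(CC)(CC)C1=O` gives 33 uM. Compound 2 `CCC1=C(O)c2c(oc(-c3cccc(F)c3)cc2=O)C(CC)(CC)C1=O` is reported only as a limit of the assay, > 56.2 uM. Compound 3 `CCC1=C(O)c2c(oc(-c3cc(C)c(C)cc3C)cc2=O)C(CC)(CC)C1=O` gives 8.2 uM, the lowest number of the set. Compound 4 `CCC1=C(O)c2c(oc(-c3ccc(O)c(C)c3C)cc2=O)C(CC)(CC)C1=O` differs from compound 3 in one group: 4-hydroxy-2,3-dimethylphenyl in place of 2,4,5-trimethylphenyl on an aromatic carbon. Swaps at this same place have already moved the numbers, with a 4.0-fold lower number from compound 1 to compound 3 (0.60 log units; beyond the scatter) and an at least 6.8-fold lower number from compound 2 to compound 3 (0.83 log units; beyond the scatter). Going by the values given here, no measured compound carries a hydroxy group, so these steps give only a rough guide to size. A modest rise in this assay is therefore expected, similar to the size of a 4.0-fold lower number from compound 1 to compound 3 (0.60 log units; beyond the scatter), and the expected change is a 2.2-fold higher number from compound 3 to compound 4 (0.34 log units; beyond the scatter). For compound 4, the estimate is 18 uM, with an expected range of 6 uM to 50 uM.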

Compound 4, concentration for half-maximal effect: 6.5 uM
For compound 4 the middle estimate is 2.8-fold (0.44 log units) above the measured one; the measured number falls inside the stated range.
By their numbers in this assay, from the lowest: compounds 4 and 3 (each within the scatter of the next); then compound 1. At a limit, above all of these: compound 2.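

In this assay the hydroxy group, the only one among these compounds, brings a hydrogen-bond donor onto this ring with no clear shift in the number: a 1.3-fold lower number from compound 3 to compound 4 (0.10 log units; within the scatter). Compounds 3 and 4, both with methyl-bearing rings, stand apart from the fluorophenyl compounds, with a 5.1-fold lower number from compound 1 to compound 4 (0.71 log units; beyond the scatter) and an at least 8.6-fold lower number from compound 2 to compound 4 (0.93 log units; beyond the scatter). That last step starts from a limit, not a number: the limit of > 56.2 uM in this assay, at which 1 of the 4 values shown sits.

The swap also rearranges the methyl groups, so the compounds shown do not separate their part from that of the hydroxy group. On these data alone, how a methoxy group or an amine at that ring position would read stays open.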